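This account rests on a few compounds, and the source may have more. Where it says the series, first, only, none or still open, it means among the compounds named here.

In a functional assay on PC-3 cells (Homo sapiens) for antiproliferative activity, read by MTT assay, with a stated time of 24 h (on this read-out higher numbers stand for weaker inhibition and lower numbers for stronger inhibition), compound 1 `CCn1c(C(=O)NCCN)ccc1C(CC)(CC)c1ccc(OCS(=O)(=O)c2ccccc2)c(C)c1`, with its 2-aminoethyl group on the amide-type nitrogen, gives 6890 nM. Compound 2 `CCn1c(C(=O)NCC(=O)O)ccc1C(CC)(CC)c1ccc(OCS(=O)(=O)c2ccccc2)c(C)c1` gives 30100 nM, and the change is a 4.4-fold higher number from compound 1 to compound 2 (0.64 log units; beyond the scatter). Compound 3 `CCn1c(C(=O)N[C@H](CC(=O)O)C(=O)O)ccc1C(CC)(CC)c1ccc(OCS(=O)(=O)c2ccccc2)c(C)c1` returns no number, only a limit of > 50000 nM. Leaving the 2-aminoethyl group for 1,2-dicarboxyethyl is an at least 7.2-fold higher number from compound 1 to compound 3 (0.86 log units; beyond the scatter).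

Compound 4 `CCn1c(C(=O)N[C@H](CCC(=O)O)C(=O)O)ccc1C(CC)(CC)c1ccc(OCS(=O)(=O)c2ccccc2)c(C)c1` has carboxymethyl in place of carboxy on a saturated chain carbon, two bonds along the chain from an amide-type nitrogen and a carbonyl carbon, which turns 1,2-dicarboxyethyl into 1,3-dicarboxypropyl (carboxymethyl in place of carboxy on a saturated chain carbon, two bonds along the chain from an amide-type nitrogen and a carbonyl carbon). Among the compounds with values here, no measured step makes this exchange. The nearest is the addition of carboxymethyl in place of hydrogen, an at least 1.6-fold higher number from compound 2 to compound 3 (0.22 log units; that floor lies within the scatter). The two steps away from the 2-aminoethyl group do not apply, since that group is already gone from compound 3. In this assay, no change beyond the scatter is therefore expected, and the reading may again be only a limit. The expected step is an at least 1.1-fold lower number from compound 3 to compound 4 (0.04 log units; that floor lies within the scatter). Compound 4 is estimated at 45000 nM, within a range of 20000 nM to 90000 nM.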

Compound 4, half-maximal inhibitory concentration: > 50000 nM
Compound 4: a limit, no number; the forecaster's own chance of this, stated with the estimate: 50%; at least 1.1-fold (0.04 log units) between middle value and limit.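

In this assay compound 4 gives only a limit, > 50000 nM, so the exchange of 1,2-dicarboxyethyl for 1,3-dicarboxypropyl does not yield a number, and the step from compound 3 cannot be read: the limit of > 50000 nM in this assay, at which 2 of the 4 values shown sit.

Replacing 2-aminoethyl with 1,3-dicarboxypropyl gives an at least 7.2-fold higher number from compound 1 to compound 4 (0.86 log units; beyond the scatter), so the longer group, like 1,2-dicarboxyethyl, stands clear of the scatter against the amine-bearing compound. Placing 2-carboxyethyl in place of hydrogen gives an at least 1.6-fold higher number from compound 2 to compound 4 (0.22 log units; that floor lies within the scatter), so this floor does not separate compound 4 from the compound with a single carboxy group.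

Where compound 3 and compound 4 actually sit relative to each other remains open. Also open, on these data alone, is how a primary amine on a longer chain than 2-aminoethyl, or a single carboxylic acid on a longer chain than carboxymethyl, would read in this assay.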